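The source may hold more compounds than are shown below. What is called first, only, known or untested is meant among the compounds shown, and "the series" means these compounds.

In a functional assay on A2780 cells (Homo sapiens) for antiproliferative activity, read by resazurin assay, with a stated time of 72 h (a lower number here means a stronger inhibitor, a higher number a weaker inhibitor), compound 1 `CN(Cc1ccccc1F)C(=O)c1cc2c(Cc3ccccc3)n[nH]c2cc1O` gives 1500 nM and compound 2 `CN(Cc1cccc(Cl)c1)C(=O)c1cc2c(Cc3ccccc3)n[nH]c2cc1O` gives 5300 nM. Compound 3 `Cc1cccc(CN(C)C(=O)c2cc3c(Cc4ccccc4)n[nH]c3cc2O)c1` has no number to start from, and its result reads "not determined" (no result reported). Compound 4 `Cc1ccc(CN(C)C(=O)c2cc3c(Cc4ccccc4)n[nH]c3cc2O)cc1` has 4-methylphenyl in place of 3-methylphenyl on a saturated chain carbon bound to an amide-type nitrogen. Among the measured compounds shown here, the only measured step at this same place is a 3.5-fold higher number from compound 1 to compound 2 (0.55 log units; beyond the scatter), a modest change that involves other groups. It shows that swapping this group can move the number, but it gives no direction for the methyl shift. With compound 3 at "not determined" (no result reported), no step size or direction can be expected in this assay, so the estimate rests on the values of compound 1 and compound 2. Compound 4 is expected near 3000 nM, within an estimated range of 1000 nM to 9000 nM.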

Compound 4, half-maximal inhibitory concentration: 6900 nM
Estimate against measurement, compound 4: 2.3-fold (0.36 log units) below, and the stated range covers the measured number.
By their numbers in this assay, from the lowest: compound 1; then compounds 2 and 4 (each within the scatter of the next).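

In this assay, 4-methylphenyl in place of 3-chlorophenyl on this saturated chain carbon makes no real difference (a 1.3-fold higher number from compound 2 to compound 4 (0.11 log units; within the scatter)), whereas 4-methylphenyl in place of 2-fluorophenyl does (a 4.6-fold higher number from compound 1 to compound 4 (0.66 log units; beyond the scatter)). Among the measured compounds, compound 1 with its 2-fluorophenyl therefore stands apart as the strongest, while compounds 2 and 4 sit together. No measurement here explains this.

Compound 3 has no result, so the shift of the methyl itself cannot be read. As far as these compounds go, whether a ring carrying an amine or a carboxylic acid would fit at this place remains open.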